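This account rests on a few compounds, and the source may have more. Where it says the series, first, only, none or still open, it means among the compounds named here.

Measured so far:
compound 1, `N#Cc1ccc(/C=N/n2c(S)nnc2-c2cnccn2)cc1`, gives 47800 nM in a functional assay, with a stated time of 30 min; on this read-out lower numbers stand for stronger inhibition and higher numbers for weaker inhibition;
compound 2, `O=[N+]([O-])c1cccc(/C=N/n2c(S)nnc2-c2cnccn2)c1`, gives 72400 nM in this assay.

Compound 2 carries the higher of the two numbers, with compound 1 as its nearest neighbour, yet the gap between them lies within the scatter, so the two cannot be ordered. Compound 3, `Sc1nnc(-c2cnccn2)n1/N=C/c1ccccc1`, is not yet measured in this assay. It differs from compound 2 by hydrogen in place of nitro on an aromatic carbon. Among the measured compounds shown here, no step between measured compounds bears on this change, so no shift beyond the scatter is expected in either direction. Compound 3 is therefore expected to give about 60000 nM, within 20000 nM to 180000 nM. This amounts to an expected 1.2-fold lower number from compound 2 to compound 3 (0.08 log units; within the scatter).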

Compound 3, half-maximal inhibitory concentration: 52400 nM
The estimate for compound 3 lay 1.1-fold (0.06 log units) above the measured number; measured number inside the range.
By their numbers in this assay, from the lowest: compounds 1, 3 and 2 (each within the scatter of the next).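

In this assay, hydrogen in place of nitro on an aromatic carbon gives a 1.4-fold lower number from compound 2 to compound 3 (0.14 log units; within the scatter), and hydrogen in place of cyano gives a 1.1-fold higher number from compound 1 to compound 3 (0.04 log units; within the scatter). With hydrogen as the reference, neither nitro in compound 2 nor cyano in compound 1 can be told apart from the bare ring of compound 3. Nothing at hand speaks to the reason for this. Going by these compounds, it remains open whether an amine, a carboxylic acid or a methoxy group on this ring would give a step beyond the scatter. Also open, on these data alone, is whether nitro or cyano would read the same on another carbon of the ring.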